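The source may report more compounds than this note shows. Statements on the series, on what has been measured and on what is new or still open speak of the compounds shown alone.

Values in a functional assay on MCF7 cells (Homo sapiens) for cytotoxicity, read by MTT assay, with a stated time of 96 h (on this read-out lower numbers stand for stronger inhibition and higher numbers for weaker inhibition), for the compounds measured so far:

- compound 1 `COc1cc(C(=O)c2cn(-c3cccc(C)c3)cc2-c2cccc([N+](=O)[O-])c2)cc(OC)c1OC` gives 880 nM
- compound 2 `COc1cc(C(=O)c2cn(-c3cccc(C)c3)cc2-c2ccc([N+](=O)[O-])cc2)cc(OC)c1OC` gives 780 nM
- compound 3 `COc1cc(C(=O)c2cn(-c3cccc(C)c3)cc2-c2cccc(N)c2)cc(OC)c1OC` gives 130 nM

Compound 3 has the lowest number of the three. The two nitro compounds do not separate, since a 1.1-fold lower number from compound 1 to compound 2 (0.05 log units; within the scatter) stays within the usual scatter. Compound 3 lies clearly lower than either of them, as a 6.8-fold lower number from compound 1 to compound 3 (0.83 log units; beyond the scatter) and a 6.0-fold lower number from compound 2 to compound 3 (0.78 log units; beyond the scatter) both show.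

The next compound is compound 4 `COc1cc(C(=O)c2cn(-c3cccc(N)c3)cc2-c2cccc(N)c2)cc(OC)c1OC` and it keeps everything in compound 3 except one group. The change is amino in place of methyl on an aromatic carbon and in words it is amino in place of methyl on an aromatic carbon, turning 3-methylphenyl into 3-aminophenyl.

Among the measured compounds shown here, no measured step makes this exchange, and none alters this ring at all. The closest guide is a 6.8-fold lower number from compound 1 to compound 3 (0.83 log units; beyond the scatter) and that step also brings in an amino group. It replaces nitro, however, at a different place in the molecule. It is therefore weak evidence, and it gives only a slight lean towards a lower number.

An expected 1.4-fold lower number from compound 3 to compound 4 (0.16 log units; within the scatter) would be small and would probably not stand clear of the scatter. Compound 4 is expected near 90 nM with 20 nM to 400 nM as the estimated span.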

Compound 4, half-maximal inhibitory concentration: 60 nM
For compound 4 the middle estimate is 1.5-fold (0.18 log units) above the measured one; measured number inside the range.
By their numbers in this assay, from the lowest: compound 4; then compound 3; then compounds 2 and 1 (each within the scatter of the next).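

In this assay, among the compounds shown here, compound 1, compound 2 and compound 3 all carry the same 3-methylphenyl group, so they say nothing about this ring, and the exchange for 3-aminophenyl gives the first reading of it: a 2.2-fold lower number from compound 3 to compound 4 (0.34 log units; beyond the scatter). The step is modest but beyond the usual scatter, so the methyl group is not needed for activity here, and a single carbon-for-nitrogen change at this site moves the number lower. Nothing measured here accounts for the lower number.

Methyl and amino are the only two groups shown on this ring, so it remains open how a hydroxyl, a methoxy or a dimethylamino group would compare in the same place. Going by these compounds, it is also open whether this exchange would give a step of similar size in a compound that keeps a nitro group on the other aromatic ring, since here it was read only with an amino group already present there.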